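Moving the ring nitrogen: a pyridin-2-yl variant

The source may report more compounds than this note shows. Statements on the series, on what has been measured and on what is new or still open speak of the compounds shown alone.

Measured compounds and their values in an assay on isolated protein for inhibition of Indoleamine 2,3-dioxygenase 1 (Homo sapiens), read by spectrophotometry; on this read-out lower numbers stand for stronger inhibition and higher numbers for weaker inhibition:
compound 1 `O=C(Cc1cccnc1)c1cc2cc(F)ccc2[nH]1`: 36000 nM
compound 2 `O=C(Cc1cccnc1)c1cc2ccccc2[nH]1`: 65000 nM
compound 3 `O=C(Cc1cccnc1)c1cc2cc(Br)ccc2[nH]1`: 18000 nM

Compound 2 has the highest number of the three. The step from compound 1 to compound 2, a 1.8-fold higher number from compound 1 to compound 2 (0.26 log units; within the scatter), is within the scatter, so the two cannot be ranked, while the step of a 3.6-fold lower number from compound 2 to compound 3 (0.56 log units; beyond the scatter) sets compound 3 apart by a modest margin.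

Compound 4 `O=C(Cc1ccccn1)c1cc2ccccc2[nH]1` keeps every atom of compound 2 but joins them differently: pyridin-2-yl in place of pyridin-3-yl on a saturated chain carbon bound to a carbonyl carbon. Among the compounds with values here, none of the measured steps touches this part of the molecule; all three concern a halogen or hydrogen on the aromatic carbon of the shared core, and they span at most the modest 3.6-fold lower number from compound 2 to compound 3 (0.56 log units; beyond the scatter). The data therefore give no direction for this change, and the expectation is a step no larger than the scatter, a 1.1-fold higher number from compound 2 to compound 4 (0.03 log units; within the scatter), with wide uncertainty. Compound 4 is estimated at 70000 nM, expected to fall between 20000 nM and 250000 nM in this assay.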

Compound 4, half-maximal inhibitory concentration: 37000 nM
For compound 4 the middle estimate is 1.9-fold (0.28 log units) above the measured one, and the stated range covers the measured number.
By their numbers in this assay, from the lowest: compounds 3, 1, 4 and 2 (each within the scatter of the next, the first and the last beyond it).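

In this assay, the exchange of pyridin-3-yl for pyridin-2-yl on a saturated chain carbon bound to a carbonyl carbon gives a 1.8-fold lower number from compound 2 to compound 4 (0.24 log units; within the scatter) and so leaves the two compounds unranked. The earlier steps shown here all concerned a halogen or hydrogen on the shared core, whereas this pair reads the side of the molecule carrying the pyridine, and there, with the same atoms joined differently, the result stays within the scatter on a core that carries only hydrogen at the halogen-bearing carbon. Nothing available accounts for the result or shows how the two pyridine groups differ in their effect on this protein.

Going by these compounds, it remains open whether pyridin-4-yl or a plain phenyl ring at this place would give a step beyond the scatter. Also open, on these data alone, is whether pyridin-2-yl would hold with the bromo group of compound 3, which gives 18000 nM with pyridin-3-yl.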